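The compounds below may be only part of what the source reports. "The series", "measured", "known", "first", "only" and "open" are said of these compounds alone.

In an ADME assay on microsomes from liver (Homo sapiens) for metabolic stability (a higher number here means faster removal of the compound, a lower number slower removal), two compounds have been measured so far:

compound 1, `COc1ccn2c(-c3ccc(NC(=O)c4ccc([N+](=O)[O-])o4)cc3)cnc2c1`, giving 74.2 mL.min-1.g-1
compound 2, `COc1ccn2c(-c3ccc(NC(=O)c4ccc([N+](=O)[O-])o4)c(C)c3C(F)(F)F)cnc2c1`, giving 41.9 mL.min-1.g-1

For the measured compounds named here, compound 2 and compound 1 are the only two numbers in this assay, and the gap between them lies within the usual scatter of repeated measurements, so the two cannot be told apart on this evidence; compound 2 simply sits alongside compound 1.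

Compound 3, `COc1ccn2c(-c3ccc(NC(=O)c4ccc([N+](=O)[O-])o4)c(C)c3)cnc2c1`, has not been measured yet. It differs from compound 2 in one place: hydrogen in place of trifluoromethyl on an aromatic carbon. The methyl group that compound 2 carries stays in place, so compound 3 sits structurally between compound 1, which has neither methyl nor trifluoromethyl, and compound 2, which has both.

Going by the values given here, since no step between measured compounds is known, the expectation rests only on the two numbers given. Because compound 1 without either group gives 74.2 mL.min-1.g-1, compound 3 is expected to land near that number or near compound 2, with any step from compound 2 to compound 3 of a 1.3-fold higher number from compound 2 to compound 3 (0.12 log units; within the scatter) expected to stay within the scatter. The estimate for compound 3 in this assay is therefore 55 mL.min-1.g-1, with a range from 28 mL.min-1.g-1 to 110 mL.min-1.g-1.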

Compound 3, intrinsic clearance in microsomes: 52.6 mL.min-1.g-1
For compound 3 the middle estimate is 1.0-fold (0.02 log units) above the measured one; the measured number falls inside the stated range.
By their numbers in this assay, from the lowest: compounds 2, 3 and 1 (each within the scatter of the next).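

Read alone, the change at this aromatic carbon, ortho to a methyl group, gives a 1.3-fold higher number from compound 2 to compound 3 (0.10 log units; within the scatter) in this assay, so hydrogen and trifluoromethyl cannot be told apart here, even though four heavy atoms leave the molecule. The second new comparison isolates the methyl group on the aromatic ring of the core, with methyl in place of hydrogen giving a 1.4-fold lower number from compound 1 to compound 3 (0.15 log units; within the scatter), and this change also cannot be told apart from the scatter. Compound 1 and compound 2 differ in two places at once, so their pair could not show what either group does alone; compound 3 separates the two changes and shows that, taken singly, neither produces a step beyond the scatter in this assay.

From the compounds shown here alone, it remains open whether a different group on the same aromatic carbon, such as a nitrile, an amine, a hydroxyl group or a longer chain, would give a number clearly apart from these three, and whether the same changes would read the same way on a different core. Nothing here addresses what lies behind these numbers.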